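Swapping chloro for nitro on an enone acetate

A few compounds are considered here, and "the series" means these few. Any claim that something is new, unique, unknown or untested is made for them only; others in the source may bear on it.

Among the compounds with values here, compound 1, `CC(=O)OC/C(=C\c1ccc(Cl)cc1)C(=O)c1ccccc1`, is the stronger of the two compounds measured so far. In a functional assay on T47D cells (Homo sapiens) for inhibition, read by sulforhodamine B assay, with a stated time of 48 h (on this read-out lower numbers stand for stronger inhibition of growth and higher numbers for weaker inhibition of growth), compound 1 gives 5300 nM, the lower of the two numbers. Within the data shown here, its only measured neighbour is compound 2, `CC(=O)OC/C(=C\c1ccccc1F)C(=O)c1ccccc1`, which in this assay gives 18000 nM. That step, a 3.4-fold higher number from compound 1 to compound 2 (0.53 log units; beyond the scatter), came with 2-fluorophenyl in place of 4-chlorophenyl, so it moved both the kind of halogen and where it sits, and it pointed toward weaker growth inhibition. Compound 3, `CC(=O)OC/C(=C\c1ccc([N+](=O)[O-])cc1)C(=O)c1ccccc1`, has not been measured yet. It differs from compound 1 by nitro in place of chloro on an aromatic carbon, para to a large group. Among the measured compounds shown here, no measured step exchanges a group at this position alone, and the one step known swaps a different halogen at a different place, so it bears on the new change only loosely. With the substitution pattern of compound 1 kept and only the group exchanged, the expected change is small: in this assay the step of a 1.2-fold lower number from compound 1 to compound 3 (0.07 log units; within the scatter) is expected to stay within the scatter. Compound 3 is therefore estimated at 4500 nM, with a range from 1500 nM to 13000 nM.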

Compound 3, concentration for 50% growth inhibition: 16000 nM
For compound 3 the middle estimate is 3.6-fold (0.55 log units) below the measured one; measured number above the stated range.
By their numbers in this assay, from the lowest: compound 1; then compounds 3 and 2 (each within the scatter of the next).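

This step isolates the position in a way the earlier comparison could not, since the move to compound 2 changed the halogen and its place together. In this assay, the group on this aromatic carbon was exchanged while its place stayed fixed, and a 3.0-fold higher number from compound 1 to compound 3 (0.48 log units; beyond the scatter) shows that growth inhibition depends on which group sits there: nitro gives weaker inhibition than chloro. No measurement shown here accounts for this difference between the two groups.

With only chloro and nitro compared at this place, two examples cannot establish a trend, and it remains unclear whether chloro is especially favourable or nitro especially poor, so a methoxy group, an amine or a carboxylic acid on the same carbon would help to separate those possibilities. On these data alone, it also remains open whether the same exchange would have a similar effect with the acetate on the chain replaced by a hydroxyl group or a longer ester, or with nitro placed elsewhere on the ring.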